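A few compounds are considered here, and "the series" means these few. Any claim that something is new, unique, unknown or untested is made for them only; others in the source may bear on it.

Working notes on the series in an ADME assay on MT4 cells (Homo sapiens) for cytotoxicity, read by MTT assay, with a stated time of 5 days; a higher number here means that more compound is tolerated, a lower number that less compound is tolerated.

Compound 1 `CCOC(=O)C(=O)CC(=O)c1ccc(O)cc1` is the small parent; in this assay compound 1 gives 466000 nM, the highest of the three numbers. Compound 2 `CCOC(=O)C(=O)CC(=O)c1ccc(Oc2ccnc(Nc3ccc(C#N)cc3)n2)cc1` carries a much larger part in place of the hydroxy group; in this assay compound 2 gives 18000 nM. The difference between the core of compound 1 and the core of compound 2 is not broken down here. Compound 3 `N#Cc1ccc(Nc2nccc(Oc3ccc(C(=O)CC(=O)C(=O)O)cc3)n2)cc1` is the acid of compound 2, the change being (hydrogen in place of ethyl on an oxygen next to a carbonyl group). In this assay compound 3 gives 42000 nM, and the step is a 2.3-fold higher number from compound 2 to compound 3 (0.37 log units; beyond the scatter).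

Compound 4 `O=C(O)C(=O)CC(=O)c1ccc(O)cc1` is the unmeasured acid of compound 1; the change is hydrogen in place of ethyl on an oxygen next to a carbonyl group, the same change as from compound 2 to compound 3, made on the smaller core. Because the matched step was a 2.3-fold higher number from compound 2 to compound 3 (0.37 log units; beyond the scatter), a step of about the same modest size and direction is expected from compound 1 to compound 4, namely a 1.7-fold higher number from compound 1 to compound 4 (0.23 log units; within the scatter). Compound 4 is therefore expected to give 800000 nM, with a range of 350000 nM to 1800000 nM; since compound 1 already stands high, a limit rather than a number is a real possibility.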

Compound 4, half-maximal cytotoxic concentration: > 600000 nM
Compound 4 gave a limit, no number; the forecaster's own chance of this, stated with the estimate: 35%; the middle value is on the limit's open side.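

In this assay compound 4 gives > 600000 nM, which is a limit of the assay and not a number. The change from ethoxycarbonyl to carboxy on the core of compound 1 gives an at least 1.2-fold higher number from compound 1 to compound 4 (0.10 log units; that floor lies within the scatter); this is compatible with a step in the same direction as on the larger core, but it does not show a step of equal size, nor, taken alone, a step beyond the scatter. Carrying the change from one core to the other can therefore be read only this far: the same change on two cores in this assay, a 2.3-fold higher number (0.37 log units; beyond the scatter) from compound 2 to compound 3 and an at least 1.2-fold higher number (0.10 log units; that floor lies within the scatter) from compound 1 to compound 4; the limit leaves it open whether they differ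

The compounds shown leave open how a methyl ester, a longer chain on the same oxygen, or an amide in place of the ester would read on either core. Going by these compounds alone, they also leave open whether the change would give a step of similar size on a third core, since the series offers only one matched pair with a number at both ends.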